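The source may hold more compounds than are shown below. What is called first, only, known or untested is meant among the compounds shown, and "the series" means these compounds.

Measured so far in an ADME assay on HepG2 cells (Homo sapiens), read by MTT assay, with a stated time of 72 h, in the presence of a further agent that is not named here (a lower number here means a stronger inhibitor, a higher number a weaker inhibitor), and shown here with structures and values:

- compound 1 `O=C(NCc1ccccc1)Oc1ccc(Cl)cc1C(=O)Nc1ccc(F)cc1` with 34200 nM
- compound 2 `O=C(NC1CCCCC1)Oc1ccccc1C(=O)Nc1ccccc1` with 51500 nM
- compound 3 `O=C(NC1CCCCC1)Oc1ccc(Cl)cc1C(=O)Nc1ccc(F)cc1` with 8600 nM

The numbers for compound 2 and compound 1 lie within the usual scatter of each other, so these two share the upper end of this small set. Compound 3 has a clearly lower number than compound 2.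

The next compound to be measured is compound 4 `O=C(NCc1ccccc1)Oc1ccccc1C(=O)Nc1ccccc1`, which keeps the core of compound 2 and changes one group, with benzyl in place of cyclohexyl on an amide-type nitrogen.

Among the measured compounds shown here, only one measured step involves the same two groups, and it runs the opposite way, on a different core. That step, a 4.0-fold lower number from compound 1 to compound 3 (0.60 log units; beyond the scatter), is modest in size. Read in reverse, it leads to the expectation of a modestly higher number in this assay on going to compound 4. A single step on another core is thin support, so the expected size is uncertain, and the test may report only a limit here. The step estimated here is a 2.9-fold higher number from compound 2 to compound 4 (0.46 log units; beyond the scatter) at its middle. For compound 4 the estimated value is 150000 nM, with a range of 60000 nM to 400000 nM expected.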

Compound 4, half-maximal inhibitory concentration: 54300 nM
Compound 4: middle estimate off by 2.8-fold (0.44 log units), on the high side, outside the stated range (below it).
By their numbers in this assay, from the lowest: compound 3; then compounds 1, 2 and 4 (each within the scatter of the next).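

In this assay, putting benzyl in place of cyclohexyl on the amide-type nitrogen gives a 1.1-fold higher number from compound 2 to compound 4 (0.02 log units; within the scatter), so on the core of compound 2 these two groups cannot be told apart. Among the compounds shown here, until now, the only reading of this pair of groups was a 4.0-fold lower number from compound 1 to compound 3 (0.60 log units; beyond the scatter), on the core of compound 1, which carries a chlorine and a fluorine that the core of compound 2 lacks, and that single step could have suggested that cyclohexyl generally gives the lower number. The new result shows instead that the size of this change is not fixed and depends on the core that carries it: the same change on two cores in this assay, a 4.0-fold lower number (0.60 log units; beyond the scatter) from compound 1 to compound 3 and a 1.1-fold lower number (0.02 log units; within the scatter) from compound 4 to compound 2, 3.8-fold (0.58 log units) apart, beyond the scatter of two such steps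

The compounds shown carry the chlorine and the fluorine either together or not at all, so it remains open whether one of these atoms alone, or only the two together, goes with the larger step. Also open, on these data alone, is whether a different group on this nitrogen, such as a longer carbon chain or a chain ending in an amine, would give a number clearly apart from those of cyclohexyl and benzyl on either core.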